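Morpholine amide in place of the methyl ester

The source may hold more compounds than are shown below. What is called first, only, known or untested is meant among the compounds shown, and "the series" means these compounds.

Measured in a functional assay on KB cells (Homo sapiens) for inhibition, read by sulforhodamine B assay, with a stated time of 72 h; a lower number here means a stronger inhibitor of growth, a higher number a weaker inhibitor of growth:
compound 1 `CN1CCN(C(=O)/C=C/c2ccncc2-c2ccc3ccccc3c2)CC1`: > 10000 nM (a limit)
compound 2 `O=C(O)/C=C/c1ccncc1-c1ccc2ccccc2c1`: > 10000 nM (a limit)
compound 3 `COC(=O)/C=C/c1ccncc1-c1ccc2ccccc2c1`: 6730 nM

Within the data shown here, compound 3, at 6730 nM, holds the only actual number in this assay. The other two compounds sit at a limit: the limit of > 10000 nM in this assay, at which 2 of the 3 values shown sit.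

The next compound is compound 4 `O=C(/C=C/c1ccncc1-c1ccc2ccccc2c1)N1CCOCC1`, and the change is morpholin-4-yl in place of methoxy on a carbonyl carbon.

The measured steps that bear on this are at the same carbonyl carbon. One is an at least 1.4-fold lower number from compound 1 to compound 3 (0.17 log units; that floor lies within the scatter), which exchanges 4-methylpiperazin-1-yl for methoxy. Another is an at least 1.4-fold lower number from compound 2 to compound 3 (0.17 log units; that floor lies within the scatter). Both are floors only, and neither shows a change beyond the scatter. The third, a step that the two limits leave unreadable from compound 1 to compound 2, gives no size.

Compound 1 is the nearest guide, with a six-membered ring on that carbonyl carbon in place of methoxy, and it stands at the limit of > 10000 nM. A small move toward a higher number is therefore expected, one that may stay within the scatter and may end at the limit.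

The expected step is a 1.5-fold higher number from compound 3 to compound 4 (0.17 log units; within the scatter).

For compound 4 the estimated value is 10000 nM, with an expected range of 4000 nM to 30000 nM.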

Compound 4, concentration for 50% growth inhibition: > 10000 nM
Compound 4 was reported as a limit (the forecaster's own chance of this, stated with the estimate: 60%); the middle value lies on the limit itself.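

In this assay compound 4 carries a limit, > 10000 nM, and not a number. Against the methyl ester, the exchange of methoxy for morpholin-4-yl on this carbonyl carbon reads as an at least 1.4-fold higher number from compound 3 to compound 4 (0.17 log units; that floor lies within the scatter), so the morpholine amide is not separated from compound 3 beyond the scatter, and the true size of the step stays unknown. New here is that a second amide with a six-membered ring on this carbonyl carbon, after the 4-methylpiperazin-1-yl of compound 1, also yields no number, and the steps from compound 1 and compound 2 to compound 4 cannot be read, leaving the series mostly at one ceiling: the limit of > 10000 nM in this assay, at which 3 of the 4 values shown sit.

Among these compounds, compound 3 remains the only compound with a number, so it stays open whether another group on this carbonyl carbon, such as an ethoxy group, a primary amide or a dimethylamino group, would give a readable value. Also open, as far as these compounds go, is whether compound 1, compound 2 and compound 4 differ from one another at all, since their limits hide any true values.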